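From compound 1 to compound 4: a chlorophenyl amide

A few compounds are considered here, and "the series" means these few. Any claim that something is new, unique, unknown or untested is made for them only; others in the source may bear on it.

In a functional assay on HO8910 cells (Homo sapiens) for inhibition, read by MTT assay, with a stated time of 24 h, tested at 100 ug/mL (on this read-out higher numbers stand for more inhibition of growth at the one concentration tested and lower numbers for less inhibition of growth), compound 1 (`CC(=O)SCCC(CCCCC(=O)O)SC(C)=O`) gives "not active" (no number reported), so it has no number to serve as a baseline. Compound 3 (`O=C(CCCCC(S)CCS)Nc1cccc2ccccc12`) also gives "not active" (no number reported), and compound 2 (`O=C(CCCCC1CCSS1)Nc1ccc([N+](=O)[O-])c(C(F)(F)F)c1`) gives 47.7%. The next compound to test is compound 4 (`CC(=O)SCCC(CCCCC(=O)Nc1ccc(Cl)cc1)SC(C)=O`). The structural change is (4-chlorophenyl)amino in place of hydroxy on a carbonyl carbon, with (4-chlorophenyl)amino in place of hydroxy on a carbonyl carbon. A moderate rise in growth inhibition over compound 1 is expected. Compound 2, also an amide, supports this with 47.7%. Compound 3, another amide, goes against it with "not active" (no number reported), so a result without a number remains possible. For compound 4 the estimated value is 25%, with an expected range of 5% to 50%.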

Compound 4, percent growth inhibition at one concentration: 58.8%
The estimate for compound 4 lay 33.8 percentage points below the measured number, and the stated range ends below it.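

In this assay, among the compounds shown here, compound 4 gives 58.8% while compound 1 carries no number, so no step between them can be read. The compounds shown leave open how much of the growth inhibition of compound 4 goes with its (4-chlorophenyl)amino group. No evidence bears on this result.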